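Removing a Methyl from a Fused Core: Two Matched Pairs

The compounds below may be only part of what the source reports. "The series", "measured", "known", "first", "only" and "open" are said of these compounds alone.

Compound 1 `C/C(=N/O)c1ccc(NC(=O)CSc2nc3c([nH]2)c(=O)n(C)c(=O)n3C)cc1` and compound 2 `C/C(=N/O)c1ccc(NC(=O)CSc2nc3[nH]c(=O)n(C)c(=O)c3[nH]2)cc1` share a core and differ in a single place, (hydrogen in place of methyl on an aromatic nitrogen). In a functional assay on HT-29 cells (Homo sapiens) for inhibition, read by MTT assay, with a stated time of 48 h (on this read-out lower numbers stand for stronger inhibition and higher numbers for weaker inhibition), compound 1 gives 3100 nM, and compound 2 gives 6200 nM, which is a 2.0-fold higher number from compound 1 to compound 2 (0.30 log units; within the scatter). Compound 3 `Cn1c(=O)c2[nH]c(SCC(=O)c3ccccc3)nc2n(C)c1=O` carries a different side chain on a related core; the difference between the core of compound 1 and the core of compound 3 is not broken down here. In this assay compound 3 gives 5900 nM, a value lying within the usual scatter of both compound 1 and compound 2. Compound 4 `Cn1c(=O)[nH]c2nc(SCC(=O)c3ccccc3)[nH]c2c1=O` has not yet been measured. It differs from compound 3 by hydrogen in place of methyl on an aromatic nitrogen, the same change as between compound 1 and compound 2, made at the same place. Compound 4 is expected to follow compound 3 by about the same small step, a 1.7-fold higher number from compound 3 to compound 4 (0.23 log units; within the scatter). Within the data shown here, that expectation rests on the one earlier pair, compound 1 and compound 2, which showed a 2.0-fold higher number from compound 1 to compound 2 (0.30 log units; within the scatter). Compound 4 is therefore estimated to give about 10000 nM in this assay, with a plausible range from 4000 nM to 25000 nM.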

Compound 4, half-maximal inhibitory concentration: 11100 nM
For compound 4 the middle estimate is 1.1-fold (0.05 log units) below the measured one; low and high end bracket the measured number.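

In this assay, putting hydrogen in place of the methyl on the aromatic nitrogen gives a 1.9-fold higher number from compound 3 to compound 4 (0.27 log units; within the scatter). Set beside the earlier matched pair, the new step shows that this change carried over from one core to the other with much the same size: the same change on two cores in this assay, a 2.0-fold higher number (0.30 log units; within the scatter) from compound 1 to compound 2 and a 1.9-fold higher number (0.27 log units; within the scatter) from compound 3 to compound 4, 1.1-fold (0.03 log units) apart, within the scatter of two such steps. This agreement does not show that the change itself has a real effect, since each step on its own lies within the scatter, and two pairs cannot set a rule for other cores in the series.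

The compounds shown carry only methyl or hydrogen on this nitrogen, so the effect of an ethyl group or a longer chain at that place remains open. Also open, going by these compounds, is whether the two steps would still agree on a core whose side chain ends in a carboxylic acid or an amine.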